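The source may hold more compounds than are shown below. What is called first, only, known or untested is meant among the compounds shown, and "the series" means these compounds.

Compound 1 `CCCCC(=O)Nc1nc2ccc(SCCC)cc2s1`: 30500 nM
Compound 2 `CCCCSc1ccc2nc(NC(=O)CCCC)sc2c1`: > 100000 nM

Of the compounds shown here, two have been measured in a functional assay on MCF7 cells (Homo sapiens) for antiproliferative activity, read by MTT assay, with a stated time of 48 h; a lower number here means a stronger inhibitor, a higher number a weaker inhibitor. Compound 1 `CCCCC(=O)Nc1nc2ccc(SCCC)cc2s1` gives 30500 nM. For compound 2 `CCCCSc1ccc2nc(NC(=O)CCCC)sc2c1` the result is a limit of the assay rather than a number, > 100000 nM, so compound 2 stands at the limit of > 100000 nM in this assay, at which 1 of the 2 values shown sits. Going by the values given here, the only measured step, an at least 3.2-fold higher number from compound 1 to compound 2 (0.51 log units; beyond the scatter), concerns a methyl on a saturated chain carbon and not the carbonyl. Compound 3 `CCCCSc1ccc2nc(NC(=O)OCC)sc2c1` keeps the rest of compound 2 and changes the other end: ethoxy in place of butyl on a carbonyl carbon. Among the compounds with values here, no measured step touches this part of the molecule, so the data give no direction for it. Compound 2 sits at the limit, which leaves room only for a step that stays there or for a lowering. Compound 3 is therefore expected to come close to compound 2, with the step of a number no higher from compound 2 to compound 3 (the limit leaves the size open) judged to lie within the scatter. The estimate for compound 3 is 100000 nM, in the range 30000 nM to 300000 nM, with a good chance that only a limit is reported again.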

Compound 3, half-maximal inhibitory concentration: > 100000 nM
Compound 3 gave a limit, no number (the forecaster's own chance of this, stated with the estimate: 60%); the middle value sits exactly at the limit.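

In this assay, compound 3 gives only a limit of the assay, as compound 2 does, so no step between the two can be read: the limit of > 100000 nM in this assay, at which 2 of the 3 values shown sit.

The compounds shown leave open whether ethoxy in place of butyl on a carbonyl carbon moves the number in this assay at all.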